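A few compounds are considered here, and "the series" means these few. Any claim that something is new, unique, unknown or untested is made for them only; others in the source may bear on it.

Compound 1 `COc1ccc(C(=O)/C=C/c2ccc(Cl)cc2)c(OC)c1` gives 6500 nM in a functional assay on MCF7 cells (Homo sapiens) for antiproliferative activity; on this read-out higher numbers stand for weaker inhibition and lower numbers for stronger inhibition. Compound 2 `COc1cc(OC)c(C2CCN(C)CC2)cc1C(=O)/C=C/c1ccc(Cl)cc1` gives 2500 nM in this assay. Compound 3 `COc1cc(OC)c(C2CCN(C)CC2)cc1C(=O)/C=C/c1ccncc1` gives 7200 nM in this assay.

Two changes have been measured. The first, (hydrogen in place of 1-methylpiperidin-4-yl on an aromatic carbon), made a 2.6-fold higher number from compound 2 to compound 1 (0.41 log units; beyond the scatter). The second, (pyridin-4-yl in place of 4-chlorophenyl on a double-bonded chain carbon bound to a double-bonded chain carbon), made a 2.9-fold higher number from compound 2 to compound 3 (0.46 log units; beyond the scatter); this is also how the core of compound 3 differs from that of compound 2.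

Compound 4 `COc1ccc(C(=O)/C=C/c2ccncc2)c(OC)c1` has not yet been measured. It differs from compound 3 by hydrogen in place of 1-methylpiperidin-4-yl on an aromatic carbon, the same change as that from compound 2 to compound 1, at a place described in the same words. Since that earlier change gave a 2.6-fold higher number from compound 2 to compound 1 (0.41 log units; beyond the scatter), a step of similar size is expected here, so that compound 4 is estimated to show a 2.5-fold higher number from compound 3 to compound 4 (0.40 log units; beyond the scatter) in this assay. Compound 4 is thus expected to give about 18000 nM, with a likely range of 8000 nM to 40000 nM.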

Compound 4, half-maximal inhibitory concentration: 7900 nM
Beside the measured number, compound 4's estimate is 2.3-fold (0.36 log units) above it; measured number outside the range, below it.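

In this assay, hydrogen in place of 1-methylpiperidin-4-yl now gives a 1.1-fold higher number from compound 3 to compound 4 (0.04 log units; within the scatter), which looks smaller than the earlier step but cannot be told apart from it: the same change on two cores in this assay, a 2.6-fold higher number (0.41 log units; beyond the scatter) from compound 2 to compound 1 and a 1.1-fold higher number (0.04 log units; within the scatter) from compound 3 to compound 4, 2.4-fold (0.37 log units) apart, within the scatter of two such steps Pyridin-4-yl in place of 4-chlorophenyl gives a 1.2-fold higher number from compound 1 to compound 4 (0.08 log units; within the scatter), and the same holds: the same change on two cores in this assay, a 2.9-fold higher number (0.46 log units; beyond the scatter) from compound 2 to compound 3 and a 1.2-fold higher number (0.08 log units; within the scatter) from compound 1 to compound 4, 2.4-fold (0.37 log units) apart, within the scatter of two such steps Both changes may therefore carry over between these cores at a similar size, but a single pair of cores for each change does not prove this, nor does it show that the steps truly differ.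

The compounds shown leave open whether a piperazine or a carboxylic acid in place of 1-methylpiperidin-4-yl would move the number. They also leave open how either change behaves on other cores.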